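Anilino to (3-methoxyphenyl)amino: compound 2 to compound 3

A few compounds are considered here, and "the series" means these few. Any claim that something is new, unique, unknown or untested is made for them only; others in the source may bear on it.

In a functional assay on HT-29 cells (Homo sapiens) for cytotoxicity, read by sulforhodamine B assay (a higher number here means a weaker inhibitor, a lower number a stronger inhibitor), compound 1 (`C=C1[C@@H](OC(C)=O)C[C@@H]2[C@](C)(CO[Si](C)(C)C(C)(C)C)[C@H](OC(C)=O)CC[C@@]2(C)[C@@H]1C[C@@H](Nc1ccc(F)cc1)C1=CCOC1=O`) gives 4940 nM and compound 2 (`C=C1[C@@H](OC(C)=O)C[C@@H]2[C@](C)(CO[Si](C)(C)C(C)(C)C)[C@H](OC(C)=O)CC[C@@]2(C)[C@@H]1C[C@@H](Nc1ccccc1)C1=CCOC1=O`) gives 4050 nM, two values within the scatter of each other. Compound 3 (`C=C1[C@@H](OC(C)=O)C[C@@H]2[C@](C)(CO[Si](C)(C)C(C)(C)C)[C@H](OC(C)=O)CC[C@@]2(C)[C@@H]1C[C@@H](Nc1cccc(OC)c1)C1=CCOC1=O`) carries methoxy in place of hydrogen on an aromatic carbon, meta to a large group: methoxy in place of hydrogen on an aromatic carbon. Going by the values given here, the only measured step, a 1.2-fold lower number from compound 1 to compound 2 (0.09 log units; within the scatter), is hydrogen in place of fluoro on an aromatic carbon and stays within the scatter. Among the compounds with values here, no measured compound carries methoxy, so only a step within the scatter is expected, with no direction favoured. The expected step is a 1.0-fold lower number from compound 2 to compound 3 (0.01 log units; within the scatter). For compound 3 the estimated value is 4000 nM, with an expected range of 1800 nM to 9000 nM.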

Compound 3, half-maximal inhibitory concentration: > 50000 nM
Compound 3: a limit, no number; the forecaster's own chance of this, stated with the estimate: 3%; middle value at least 12-fold (1.09 log units) from the limit.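

The phenyl on the amine nitrogen is not indifferent to substitution: methoxy in place of hydrogen on an aromatic carbon, meta to a large group, gives an at least 12-fold higher number from compound 2 to compound 3 (1.09 log units; beyond the scatter), whereas the earlier exchange of fluoro for hydrogen stayed within the scatter. Against the 4-fluorophenyl compound, the 3-methoxyphenyl group gives an at least 10-fold higher number from compound 1 to compound 3 (1.00 log units; beyond the scatter). Compound 3 stands at a limit, not a number: the limit of > 50000 nM in this assay, at which 1 of the 3 values shown sits.

On these data alone, whether a hydroxy or a methyl on the same carbon would behave like methoxy stays open. So does the effect of methoxy on another carbon of this ring.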